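Swapping a Furan Ring for a Propyl Chain

The source may report more compounds than this note shows. Statements on the series, on what has been measured and on what is new or still open speak of the compounds shown alone.

Of the compounds shown here, three sharing one core have been measured in an assay on isolated protein for inhibition of aldehyde dehydrogenase 1A1 (Homo sapiens), read by spectrophotometry, tested at 10 uM; a higher number here means more inhibition at the concentration tested (going by the name of the read-out), a lower number less inhibition. Compound 1 `CC(=O)N1CCN(Cc2nc3ccccc3n2Cc2cccc(C)c2)CC1` gives 70.3%, compound 2 `CCC(=O)N1CCN(Cc2nc3ccccc3n2Cc2cccc(C)c2)CC1` gives 85.1%, and compound 3 `Cc1cccc(Cn2c(CN3CCN(C(=O)c4ccco4)CC3)nc3ccccc32)c1` gives 73.2%. Compound 3 thus stands second of the three: its number lies within the scatter of compound 1 but clearly under compound 2, since a number 11.9 percentage points lower from compound 2 to compound 3 (beyond the scatter). Compound 4 `CCCC(=O)N1CCN(Cc2nc3ccccc3n2Cc2cccc(C)c2)CC1` differs from compound 3 in one place: propyl in place of furan-2-yl on a carbonyl carbon. Within the data shown here, two measured steps bear on this. Growing the group on the carbonyl carbon helped, as a number 14.8 percentage points higher from compound 1 to compound 2 (beyond the scatter), while putting furan-2-yl in place of ethyl on that carbon lowered the read-out, as noted. Undoing that loss with a longer chain, a modest rise is expected, a number 10.8 percentage points higher from compound 3 to compound 4 (beyond the scatter). Compound 4 is therefore estimated at 84%, within 72% to 94%.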

Compound 4, a percentage reported as inhibition, at one concentration (the size of the read-out at that concentration, not a potency): 79.1%
Estimate against measurement, compound 4: 4.9 percentage points above; low and high end bracket the measured number.
By their numbers in this assay, from the lowest: compounds 1, 3, 4 and 2 (each within the scatter of the next, the first and the last beyond it).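

On the carbonyl carbon, a ring and an open chain cannot be told apart in this assay (furan-2-yl against propyl: a number 5.9 percentage points higher from compound 3 to compound 4 (within the scatter)). The propyl chain also stays within the scatter of the shorter groups, both ethyl (a number 6 percentage points lower from compound 2 to compound 4 (within the scatter)) and methyl (a number 8.8 percentage points higher from compound 1 to compound 4 (within the scatter)), so the clear gain from methyl to ethyl cannot be said to continue or to reverse. Nothing measured here explains these numbers.

Open, from the compounds shown here alone, is whether a longer chain such as butyl would separate from ethyl. Also open, going by these compounds, is how a phenyl ring or an amine would compare on this carbonyl carbon.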